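This account rests on a few compounds, and the source may have more. Where it says the series, first, only, none or still open, it means among the compounds named here.

Three compounds share one core and differ only in the group carried on the saturated chain carbon bound to the carbonyl carbon. Compound 1, `CC(C)c1cc(OCC(=O)[C@H](CC(=O)O)NC(=O)[C@@H](NC(=O)COc2cccc3ccccc23)C(C)C)no1`, in a functional assay on Jurkat cells (Homo sapiens) for inhibition (on this read-out higher numbers stand for weaker inhibition and lower numbers for stronger inhibition), gives only a limit, > 200000 nM. Compound 2, `CC(C)[C@H](NC(=O)COc1cccc2ccccc12)C(=O)N[C@@H](CC(=O)O)C(=O)CSc1nc(-c2ccccc2)no1`, gives in this assay 102000 nM. Compound 3, `CC(C)[C@H](NC(=O)COc1cccc2ccccc12)C(=O)N[C@@H](CC(=O)O)C(=O)COc1ccncn1`, likewise gives in this assay only a limit, > 200000 nM. Two of the three values sit at the same limit, (the limit of > 200000 nM in this assay, at which 2 of the 3 values shown sit), so compound 3 stands at the weak end of what the numbers show, without a number of its own. The unmeasured compound 4, `CC(C)[C@H](NC(=O)COc1cccc2ccccc12)C(=O)N[C@@H](CC(=O)O)C(=O)COc1ccc2ccccc2n1`, carries quinolin-2-yl in place of pyrimidin-4-yl on an oxygen on a saturated carbon. The measured steps give little to lean on: an at least 1.9-fold higher number from compound 2 to compound 3 (0.29 log units; that floor lies within the scatter) and a step that the two limits leave unreadable from compound 1 to compound 3 both end in a limit, and an at least 1.9-fold lower number from compound 1 to compound 2 (0.29 log units; that floor lies within the scatter) sets only a floor that stays within the scatter. Among the compounds with values here, what remains is that the one compound with a two-ring aromatic group on that chain, compound 2, returned a number, 102000 nM, while the one-ring groups of compounds 1 and 3 did not. Compound 4, with its two-ring quinolinyl group, is therefore expected to give a number of about 100000 nM, between 30000 nM and 300000 nM. This estimate means an expected step of an at least 2.0-fold lower number from compound 3 to compound 4 (0.30 log units; that floor lies within the scatter), with a real chance that the assay again reports only a limit.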

Compound 4, half-maximal inhibitory concentration: > 200000 nM
Compound 4: a limit, no number; the forecaster's own chance of this, stated with the estimate: 40%; middle value at least 2.0-fold (0.30 log units) away from the limit.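

In this assay compound 4 gives only a limit, > 200000 nM, so at this position, on an oxygen on a saturated carbon, the two-ring quinolin-2-yl group is no more readable than the one-ring pyrimidin-4-yl group, and a second ring alone does not bring a number. Against the only compound with a number, (quinolin-2-yl)oxy in place of (3-phenyl-1,2,4-oxadiazol-5-yl)sulfanyl gives an at least 1.9-fold higher number from compound 2 to compound 4 (0.29 log units; that floor lies within the scatter), so this change shows no difference beyond the scatter. The steps to compound 4 from compound 1 and from compound 3 cannot be read, and the series now crowds against one end of the read-out: the limit of > 200000 nM in this assay, at which 3 of the 4 values shown sit.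

Going by these compounds, it remains open whether the sulfanyl link or the 3-phenyl-1,2,4-oxadiazol-5-yl ring lies behind the number of compound 2, 102000 nM, a question that (quinolin-2-yl)sulfanyl or (3-phenyl-1,2,4-oxadiazol-5-yl)oxy on the same carbon could address. Also open, on these data alone, is whether an amine or a carboxylic acid on the quinolin-2-yl group would bring compound 4 into the readable range of this assay.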